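Changing the Group on the Carbonyl Carbon of Compound 1

The compounds below may be only part of what the source reports. "The series", "measured", "known", "first", "only" and "open" are said of these compounds alone.

Compound 1 `COc1ccc(-c2cnc3nc(N)nc(N4CCN(C(=O)NCc5ccccc5)CC4)c3n2)cc1OC` is the only one of the three measured compounds that yields a number in a functional assay on cells (T-cell, Homo sapiens) for inhibition; on this read-out higher numbers stand for weaker inhibition and lower numbers for stronger inhibition: in this assay compound 1 gives 18 nM. Compound 2 `CCOc1nc(N)nc2ncc(-c3ccc(Cl)c(Cl)c3)nc12` reaches only a limit of the assay, > 10000 nM. Compound 3 `CC(C)Oc1nc(N)nc2ncc(-c3ccc(C(F)(F)F)cc3)nc12` likewise stops at a limit, > 10000 nM. Within the data shown here, two of the three values therefore sit at the limit of > 10000 nM in this assay, at which 2 of the 3 values shown sit, and since no two measured compounds differ in one place only, no measured step is available to calibrate the change that follows.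

Compound 4 `COc1ccc(-c2cnc3nc(N)nc(N4CCN(C(=O)COc5ccc(Cl)cc5)CC4)c3n2)cc1OC` has not been measured. It departs from compound 1 at the carbonyl carbon whose other neighbour is the amide-type nitrogen in the ring: (4-chlorophenoxy)methyl in place of benzylamino on a carbonyl carbon. The hydrogen-bond donor of the benzylamino group is given up and one hydrogen-bond acceptor arrives with the (4-chlorophenoxy)methyl group, while an aromatic ring of carbon only is kept on both sides of the exchange.

Among the measured compounds shown here, with no measured step to lean on, the expected step is a 2.5-fold higher number from compound 1 to compound 4 (0.40 log units; beyond the scatter), a modest weakening just beyond the scatter of this assay rather than a collapse toward a limit. Compound 4 is accordingly expected to give 45 nM, with a range from 10 nM to 250 nM.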

Compound 4, half-maximal inhibitory concentration: 0.5 nM
Compound 4: the middle estimate sits 90-fold (1.95 log units) above what was measured; the measured number lies below the stated range.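

In this assay the exchange on the carbonyl carbon gives a 36-fold lower number from compound 1 to compound 4 (1.56 log units; beyond the scatter), so a carbonyl carbon whose other neighbour is an amide-type nitrogen in a ring proves to be a place where the number responds strongly, and here it moves toward stronger inhibition. The change gives up the hydrogen-bond donor of the benzylamino group, and the result for compound 4 shows that inhibition at this level does not depend on that donor. Because the exchange alters several features at once, this single step cannot assign the gain to any one of them, and nothing measured here accounts for its size.

Going by these compounds, what remains open is whether the chlorine or the oxygen of the (4-chlorophenoxy)methyl group carries the step, a question that a plain phenoxymethyl group or a 4-chlorobenzylamino group on the same carbonyl carbon would help to separate. Also open, on these data alone, is how far the gain persists with a different group in this place, such as a longer chain between the carbonyl carbon and the ring, or a chain ending in a carboxylic acid or an amine.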